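Adding chloro to compound 2: an expected small step

The source may hold more compounds than are shown below. What is called first, only, known or untested is meant among the compounds shown, and "the series" means these compounds.

Compound 1 `O=C(CCCCC1CCSS1)Nc1ccccc1Cl`: 7.74%
Compound 2 `O=C(CCCCC(S)CCS)Nc1ccccc1`: 6.38%

In a functional assay on HO8910 cells (Homo sapiens) for inhibition, read by MTT assay, with a stated time of 24 h, tested at 1 ug/mL (on this read-out lower numbers stand for less inhibition of growth and higher numbers for more inhibition of growth at the one concentration tested), compound 2 gives 6.38%, within the usual scatter of compound 1 at 7.74%. Compound 3 `O=C(CCCCC(S)CCS)Nc1ccccc1Cl` has chloro in place of hydrogen on an aromatic carbon of compound 2 (chloro in place of hydrogen on an aromatic carbon). No measured step between compounds that differ in one place is available, so the size of this change has not been shown. The estimated step of a number 1.6 percentage points higher from compound 2 to compound 3 (within the scatter) is expected to stay within the scatter, in neither direction. Compound 3 is expected to give 8%, with an estimated range from 2% to 18%.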

Compound 3, percent growth inhibition at one concentration: 7.72%
Compound 3: the middle estimate sits 0.3 percentage points above what was measured, and the stated range covers the measured number.
By their numbers in this assay, from the lowest: compounds 2, 3 and 1 (each within the scatter of the next).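

In this assay, chloro in place of hydrogen on an aromatic carbon gives a number 1.3 percentage points higher from compound 2 to compound 3 (within the scatter) and so shows no effect that can be told from the scatter at this place, ortho to a large group. The open group of 5 heavy atoms in place of the five-membered non-aromatic ring with 2 hetero atoms gives a number 0 percentage points lower from compound 1 to compound 3 (within the scatter) and likewise shows no such effect on the saturated chain carbon. No further measurement bears on these results. On these data alone, whether an amine on that aromatic carbon or a longer chain would give a number beyond the scatter stays open.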